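This account rests on a few compounds, and the source may have more. Where it says the series, first, only, none or still open, it means among the compounds named here.

Of the compounds shown here, three sharing one core have been measured in a functional assay on Ehrlich cells (Mus musculus) for cytotoxicity, read by trypan blue exclusion, with a stated time of 2 h, tested at 25 ug/mL; on this read-out lower numbers stand for a weaker effect and higher numbers for a stronger effect at the one concentration tested. Compound 1 `N#CC1=C(N)N(c2ccc(S(N)(=O)=O)cc2)C2=C(CCCC2)C1c1ccccc1O` gives 40%. Compound 2 `N#CC1=C(N)N(c2ccc(S(N)(=O)=O)cc2)C2=C(CCCC2)C1c1ccc(O)cc1` gives 42%. Compound 3 `COc1ccccc1C1C(C#N)=C(N)N(c2ccc(S(N)(=O)=O)cc2)C2=C1CCCC2` gives 40%. Compound 2 holds the highest of the three numbers, yet its step from compound 1 (a number 2 percentage points higher from compound 1 to compound 2 (within the scatter)) and its step to compound 3 (a number 2 percentage points lower from compound 2 to compound 3 (within the scatter)) both stay within the scatter, so the three compounds cannot be told apart on these numbers.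

The unmeasured compound 4 `COc1ccc(C2C(C#N)=C(N)N(c3ccc(S(N)(=O)=O)cc3)C3=C2CCCC3)cc1` differs from compound 2 in one place: methyl in place of hydrogen on an oxygen on an aromatic ring. The same change has been made once before, on the 2-hydroxyphenyl rather than the 4-hydroxyphenyl, and there no change at the digits printed from compound 1 to compound 3 (within the scatter). Among the measured compounds shown here, that single step is the only measured evidence bearing on the move to compound 4, and it showed nothing beyond the scatter. In this assay the step is therefore expected to be no change at the digits printed from compound 2 to compound 4 (within the scatter). Compound 4 is estimated at 42%, with a range from 32% to 52%.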

Compound 4, a percentage reported as activity, at one concentration (the size of the read-out at that concentration, not a potency): 90%
Compound 4: middle estimate off by 48 percentage points, on the low side; the measured number lies above the stated range.
By their numbers in this assay, from the lowest: compounds 1, 3 and 2 (each within the scatter of the next); then compound 4.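

The same methyl on an oxygen does not carry one result from one phenyl to the other in this assay: the same change on two cores in this assay, no change at the digits printed (within the scatter) from compound 1 to compound 3 and a number 48 percentage points higher (beyond the scatter) from compound 2 to compound 4, 48 percentage points apart, beyond the scatter of two such steps. Moving the methoxy group, 4-methoxyphenyl in place of 2-methoxyphenyl, gives a number 50 percentage points higher from compound 3 to compound 4 (beyond the scatter), so the place of the group on the phenyl ring counts as well. The jump appears only where methyl and that place come together: going from 2-hydroxyphenyl to 4-methoxyphenyl gives a number 50 percentage points higher from compound 1 to compound 4 (beyond the scatter), and going from 4-hydroxyphenyl to 4-methoxyphenyl gives a number 48 percentage points higher from compound 2 to compound 4 (beyond the scatter).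

The compounds shown carry only hydrogen or methyl on that oxygen, so it stays open whether an ethyl group or a longer chain there, or an amine in place of the methoxy group, would keep the number of compound 4. A reading at one concentration also leaves the potency of compound 4 open.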